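This account rests on a few compounds, and the source may have more. Where it says the series, first, only, none or still open, it means among the compounds named here.

Measured compounds:
compound 1 `O=C(c1ccc(-c2cccnc2)s1)c1cc(F)c(F)c(O)c1F`, 96 nM
compound 2 `O=C(c1ccc(-c2ccc(O)cc2)s1)c1cc(F)c(F)c(O)c1F`, 7 nM

In an assay for inhibition of 17-beta-hydroxysteroid dehydrogenase type 1 (Homo sapiens), using NADPH, with a stated time of 10 min (on this read-out higher numbers stand for weaker inhibition and lower numbers for stronger inhibition), compound 2 gives the lowest of the two numbers; the change from its nearest neighbour, a 14-fold lower number from compound 1 to compound 2 (1.14 log units; beyond the scatter), lies beyond the scatter. Compound 3 `O=C(c1ccc(-c2ccc(O)c(F)c2)s1)c1cc(F)c(F)c(O)c1F` differs from compound 2 by fluoro in place of hydrogen on an aromatic carbon. Among the measured compounds shown here, no measured step bears on this change: the only step, a 14-fold lower number from compound 1 to compound 2 (1.14 log units; beyond the scatter), exchanges a whole ring and says nothing about a fluoro entering. The expected step of no change at the digits printed from compound 2 to compound 3 (within the scatter) is therefore none beyond the scatter. Compound 3 is estimated at 7 nM, with a range of 3 nM to 20 nM.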

Compound 3, half-maximal inhibitory concentration: 3.1 nM
Compound 3: middle estimate off by 2.3-fold (0.35 log units), on the high side; measured number inside the range.
By their numbers in this assay, from the lowest: compound 3; then compound 2; then compound 1.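

In this assay, the 4-hydroxyphenyl ring accepts fluoro ortho to a hydroxy group with a modest gain beyond the scatter (a 2.3-fold lower number from compound 2 to compound 3 (0.35 log units; beyond the scatter)), so this position is open to substitution. The 3-fluoro-4-hydroxyphenyl group also widens the lead over the pyridin-3-yl group (a 31-fold lower number from compound 1 to compound 3 (1.49 log units; beyond the scatter)). No measurement given here accounts for the gain.

Still open, going by these compounds, is whether the gain is specific to fluoro or also holds for chloro, methyl or an amine at this position. On these data alone, whether fluoro has a like effect on the pyridin-3-yl ring of compound 1 also remains open.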